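The source may report more compounds than this note shows. Statements on the series, on what has been measured and on what is new or still open speak of the compounds shown alone.

Four compounds share the same central arrangement and are compared in a functional assay on HeLa cells (Homo sapiens) for antiproliferative activity, read by MTT assay; a lower number here means a stronger inhibitor, a higher number a weaker inhibitor. Compound 1, `NS(=O)(=O)c1ccc(Nc2ncc(/N=C/c3cccs3)c(NC3CCCC3)n2)cc1`, gives in this assay 10900 nM. Compound 2, `NS(=O)(=O)c1ccc(Nc2ncc(/N=C/c3ccc(C(F)(F)F)cc3)c(NC3CCCC3)n2)cc1`, gives 21900 nM. The two differ in one place only, (4-(trifluoromethyl)phenyl in place of thiophen-2-yl on a carbon with a double bond to nitrogen), and this change made a step of a 2.0-fold higher number from compound 1 to compound 2 (0.30 log units; within the scatter).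

Compound 3, `CC(C)Nc1nc(Nc2ccc(N3CCN(C)CC3)cc2)ncc1/N=C/c1cccs1`, carries a different core; how its core differs from that of compound 1 is not broken down here. In this assay compound 3 gives 77100 nM, the highest number of the three measured compounds, standing beyond the scatter from both compound 1 and compound 2.

Compound 4, `CC(C)Nc1nc(Nc2ccc(N3CCN(C)CC3)cc2)ncc1/N=C/c1ccc(C(F)(F)F)cc1`, has not yet been measured. It is related to compound 3 by the same change that turned compound 1 into compound 2, namely (4-(trifluoromethyl)phenyl in place of thiophen-2-yl on a carbon with a double bond to nitrogen); the place of the change is the same in both pairs, so this is the same change made on a different core.

Since the step from compound 1 to compound 2 stayed within the scatter, the expectation is that the same change on the core of compound 3 also gives a step of about a 1.8-fold higher number from compound 3 to compound 4 (0.26 log units; within the scatter), resting on the earlier step of a 2.0-fold higher number from compound 1 to compound 2 (0.30 log units; within the scatter). Compound 4 is therefore estimated at 140000 nM in this assay, with a likely range from 50000 nM to 400000 nM.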

Compound 4, half-maximal inhibitory concentration: > 100000 nM
Compound 4 was reported as a limit (the forecaster's own chance of this, stated with the estimate: 30%); the middle value is on the limit's open side.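

In this assay compound 4 gives > 100000 nM, which is a limit of the assay and not a number. On the core of compound 3, putting 4-(trifluoromethyl)phenyl in place of thiophen-2-yl therefore gives a step that can be stated only as a floor, an at least 1.2-fold higher number from compound 3 to compound 4 (0.11 log units; that floor lies within the scatter), so the data show neither that the change carries over unaltered to this core nor that it behaves differently there. Setting this step beside the earlier one gives a comparison that stays unsettled, and the true size of the step on the second core remains unknown: the same change on two cores in this assay, a 2.0-fold higher number (0.30 log units; within the scatter) from compound 1 to compound 2 and an at least 1.2-fold higher number (0.11 log units; that floor lies within the scatter) from compound 3 to compound 4; the limit leaves it open whether they differ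

The compounds shown cover only two cores and two groups on the carbon with a double bond to nitrogen, so they cannot tell how general the behaviour of this change is across the series. Also open, as far as these compounds go, is what a phenyl ring carrying an amine or a carboxylic acid, or a plain longer chain, would give at that place on either core, and a value for compound 4 that is a real number rather than a limit would be needed to size the step at all.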